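Dimethoxyphenyl in place of fluorophenyl: outlook for compound 4

This account rests on a few compounds, and the source may have more. Where it says the series, first, only, none or still open, it means among the compounds named here.

Within the data shown here, compound 3 `COc1cc2c(Oc3ccc(NC(=O)c4cc(-c5ccc(F)cc5)ccn4)cc3F)ccnc2cc1OCCCN1CCN(C)CC1` gives 1460 nM in a functional assay on HT-29 cells (Homo sapiens) for cytotoxicity, read by MTT assay, with a stated time of 72 h (on this read-out lower numbers stand for stronger inhibition and higher numbers for weaker inhibition), the highest of the three numbers so far. Compound 1 `COc1cc2c(Oc3ccc(NC(=O)c4cc(-c5ccc(F)cc5)ccn4)cc3F)ccnc2cc1OCCCN1CCCCC1` gives 1370 nM, and a 1.1-fold higher number from compound 1 to compound 3 (0.03 log units; within the scatter) sits within the scatter. Among the measured compounds shown here, compound 2 `COc1cc2c(Oc3ccc(NC(=O)c4cc(-c5ccc(C(F)(F)F)cc5)ccn4)cc3F)ccnc2cc1OCCCN1CCCCC1` gives 230 nM, well below compound 3; a 6.0-fold lower number from compound 1 to compound 2 (0.77 log units; beyond the scatter) is the only step beyond the scatter in the set. Compound 4 `COc1ccc(-c2ccnc(C(=O)Nc3ccc(Oc4ccnc5cc(OCCCN6CCN(C)CC6)c(OC)cc45)c(F)c3)c2)c(OC)c1` differs from compound 3 by 2,4-dimethoxyphenyl in place of 4-fluorophenyl on an aromatic carbon. For the measured compounds named here, that step from compound 1 to compound 2 alters the same ring, but no measured pair exchanges a fluoro-bearing phenyl for a dimethoxyphenyl, so its direction cannot be read across. A small shift is expected, with compound 4 estimated at 900 nM, range 250 nM to 3200 nM, i.e. an expected 1.6-fold lower number from compound 3 to compound 4 (0.21 log units; within the scatter).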

Compound 4, half-maximal inhibitory concentration: 420 nM
Estimate against measurement, compound 4: 2.1-fold (0.33 log units) above; low and high end bracket the measured number.
By their numbers in this assay, from the lowest: compounds 2 and 4 (each within the scatter of the next); then compounds 1 and 3 (each within the scatter of the next).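

The step of a 3.5-fold lower number from compound 3 to compound 4 (0.54 log units; beyond the scatter) shows that in this assay this position, opposite the ring nitrogen, also responds to change when the chain ends in 4-methylpiperazin-1-yl; the earlier step at this position carried piperidin-1-yl. It also shows that an entering group without fluorine can lower the number. No measurement bears on the reason for this shift. Going by these compounds, whether one methoxy alone would do the same remains open, as does the outcome with an amine or a carboxylic acid on this phenyl ring.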